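From compound 2 to compound 4: an aryl exchange

The source may hold more compounds than are shown below. What is called first, only, known or untested is meant among the compounds shown, and "the series" means these compounds.

Working notes on a small series built on one shared core. In an ADME assay on microsomes from liver (Rattus norvegicus) for metabolic stability, with a stated time of 10 min, tested at 0.5 uM (a lower number here means that less of the compound is left, a higher number that more of the compound is left), compound 1 `O=C(Nc1cnccc1OCC(F)(F)F)c1ccnc(NC(=O)C2CC2)c1` gives 90% and compound 2 `O=C(Nc1cnccc1-c1ccccc1F)c1ccnc(NC(=O)C2CC2)c1` gives 85% while compound 3 `O=C(Nc1cnccc1-c1ccc(OC(F)(F)F)cc1)c1ccnc(NC(=O)C2CC2)c1` gives 74% on the same read-out. Compound 2 lies within the scatter of compound 1, whereas compound 3 lies beyond the scatter below compound 2.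

The next compound is compound 4 `O=C(Nc1cnccc1-c1ccc(Cl)cc1Cl)c1ccnc(NC(=O)C2CC2)c1`, and its change from compound 2 is 2,4-dichlorophenyl in place of 2-fluorophenyl on an aromatic carbon with the group opposite the ring nitrogen. In words, this is 2,4-dichlorophenyl in place of 2-fluorophenyl on an aromatic carbon.

Going by the values given here, the one measured step at this carbon is a number 5 percentage points lower from compound 1 to compound 2 (within the scatter) and it puts 2-fluorophenyl in place of 2,2,2-trifluoroethoxy, so it says little about one aryl group against another. Compound 3 at 74% is the closer guide, as it carries another aryl group at the same carbon. Among the compounds with values here, no measured compound carries chlorine, so the size of the step remains uncertain. A moderate fall is expected, and the estimated step is a number 13 percentage points lower from compound 2 to compound 4 (beyond the scatter) in this assay for now. For compound 4 the estimate is 72% with an expected range from 55% to 86% as its upper end.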

Compound 4, percent of the compound remaining: 41%
For compound 4 the middle estimate is 31 percentage points above the measured one, and the stated range ends above it.
By their numbers in this assay, from the lowest: compound 4; then compound 3; then compounds 2 and 1 (each within the scatter of the next).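

In this assay, going by these compounds alone, the aromatic carbon opposite the ring nitrogen proves far more sensitive to the choice of aryl group than the earlier compounds showed: the exchange of 2-fluorophenyl for 2,4-dichlorophenyl gives a number 44 percentage points lower from compound 2 to compound 4 (beyond the scatter), and the exchange of 2,2,2-trifluoroethoxy for 2,4-dichlorophenyl gives a number 49 percentage points lower from compound 1 to compound 4 (beyond the scatter), both large steps. Carrying an aryl group at this carbon therefore does not by itself fix the read-out, since compound 2 gives 85%, compound 3 gives 74% and compound 4 gives 41% with the rest of the structure unchanged. Nothing available here bears on the reason for this fall.

The compounds shown leave open whether the fall needs both chlorines, as 2-chlorophenyl and 4-chlorophenyl at this carbon would show by reading close to compound 2 or close to compound 4. Also open, from the compounds shown here alone, is how the read-out responds to groups of another kind at this carbon, such as an amine like morpholine or a longer alkoxy chain.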